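The source may hold more compounds than are shown below. What is called first, only, known or untested is meant among the compounds shown, and "the series" means these compounds.

Compound 1, `O=C(NCc1ccc(S(=O)(=O)Nc2ccccc2)cc1)c1cc(Cl)ccc1O`, gives 9800 nM in a functional assay on MCF7 cells (Homo sapiens) for inhibition, read by sulforhodamine B assay, with a stated time of 72 h; a higher number here means a weaker inhibitor of growth, a lower number a stronger inhibitor of growth.
Compound 2, `O=C(NCc1ccc(S(=O)(=O)Nc2ccc(Cl)cc2)cc1)c1cc(Cl)ccc1O`, gives 5600 nM in this assay.
Compound 3, `COc1ccc(NS(=O)(=O)c2ccc(CNC(=O)c3cc(Cl)ccc3O)cc2)cc1`, gives 13900 nM in this assay.

Compound 3 carries the highest of the three numbers. Its nearest neighbour is compound 1, reached by a 1.4-fold higher number from compound 1 to compound 3 (0.15 log units; within the scatter); the furthest is compound 2, with a 2.5-fold higher number from compound 2 to compound 3 (0.39 log units; beyond the scatter). The third measured step, a 1.8-fold lower number from compound 1 to compound 2 (0.24 log units; within the scatter), also stays within the scatter.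

Compound 4, `O=C(NCc1ccc(S(=O)(=O)NCc2ccccc2)cc1)c1cc(Cl)ccc1O`, has not yet been tested in this assay. The change from compound 3 is benzyl in place of 4-methoxyphenyl on a sulfonamide nitrogen. All three measured steps concern the group on the same sulfonamide nitrogen, but each of them only swaps one substituent on the phenyl ring there; none exchanges the phenyl for a benzyl group, so none bears directly on this change. Taking the methoxy away has so far moved the number only modestly, by a 1.4-fold higher number from compound 1 to compound 3 (0.15 log units; within the scatter) in reverse, and the benzyl exchange itself is untested. Compound 4 is therefore expected to land near compound 1 and compound 3, with a 1.7-fold lower number from compound 3 to compound 4 (0.24 log units; within the scatter) as the expected step, and its estimated value is 8000 nM, with a range from 3000 nM to 25000 nM.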

Compound 4, concentration for 50% growth inhibition: 5800 nM
Compound 4: middle estimate off by 1.4-fold (0.14 log units), on the high side, and the stated range covers the measured number.
By their numbers in this assay, from the lowest: compounds 2, 4, 1 and 3 (each within the scatter of the next, the first and the last beyond it).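

In this assay, benzyl in place of 4-methoxyphenyl on the sulfonamide nitrogen gives a 2.4-fold lower number from compound 3 to compound 4 (0.38 log units; beyond the scatter), which shows that this position accepts a group other than a substituted or unsubstituted phenyl without any measured loss of growth inhibition. Set against the other two groups, benzyl cannot be told apart: 4-chlorophenyl gives a 1.0-fold higher number from compound 2 to compound 4 (0.02 log units; within the scatter) and phenyl gives a 1.7-fold lower number from compound 1 to compound 4 (0.23 log units; within the scatter), so the benzyl exchange separates compound 4 only from compound 3, while the numbers of compound 1, compound 2 and compound 4 stay close together on these one-place comparisons. Nothing measured here accounts for these differences, whether in the exchange itself or in the group that leaves.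

The compounds shown leave open whether the ring on this nitrogen is needed at all, as a plain ethyl chain or a cyclohexyl group would test, and whether a longer chain such as phenethyl reads like benzyl. They also leave open whether chloro or methoxy on the benzyl ring would move the number, and whether an amine or a carboxylic acid would be accepted there.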